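From Chloro to Amino on the Long Chain

A few compounds are considered here, and "the series" means these few. Any claim that something is new, unique, unknown or untested is made for them only; others in the source may bear on it.

In a functional assay on SW480 cells (Homo sapiens) for antiproliferative activity, read by MTT assay, with a stated time of 48 h (a lower number here means a stronger inhibitor, a higher number a weaker inhibitor), compound 1 (`CCCCC(CCO)n1cnc2c(N)ncnc21`) gives > 50000 nM, which is a limit and not a number. Compound 2 (`CCCCCC(CCO)n1cnc2c(N)ncnc21`) gives > 50000 nM, again a limit. That leaves a step that the two limits leave unreadable from compound 1 to compound 2. Among the compounds with values here, compound 3 (`CCCCCCCCCCC(CCO)n1cnc2c(Cl)ncnc21`) gives 3160 nM, the only true number. Compound 4 (`CCCCCCCCCCC(CCO)n1cnc2c(N)ncnc21`) departs from it by amino in place of chloro on an aromatic carbon. Within the data shown here, no measured step covers this change. Among the measured compounds shown here, the only guide is that the two amino compounds with shorter chains, compound 1 and compound 2, both sit at the limit of > 50000 nM in this assay, at which 2 of the 3 values shown sit. A weakening is therefore expected, estimated as a 2.8-fold higher number from compound 3 to compound 4 (0.45 log units; beyond the scatter). Compound 4 is estimated at 9000 nM, with an expected range from 2500 nM to 32000 nM.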

Compound 4, half-maximal inhibitory concentration: 1200 nM
The estimate for compound 4 lay 7.5-fold (0.88 log units) above the measured number; measured number below the stated range.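

On the long chain, amino on this aromatic carbon beats chloro in this assay, with a 2.6-fold lower number from compound 3 to compound 4 (0.42 log units; beyond the scatter), so amino there does not by itself keep a compound weak. Lengthening the chain matters more, giving an at least 41-fold lower number from compound 2 to compound 4 (1.61 log units; beyond the scatter) and an at least 41-fold lower number from compound 1 to compound 4 (1.61 log units; beyond the scatter). Both steps start from a limit and not a number: the limit of > 50000 nM in this assay, at which 2 of the 4 values shown sit.

From the compounds shown here alone, whether chloro on a shorter chain also stays weak remains open. So does whether a methylamino group on that carbon, or a longer chain, would lower the number further.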